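The source may report more compounds than this note shows. Statements on the series, on what has been measured and on what is new or still open speak of the compounds shown alone.

Compound 2, whose structure is `Cc1csc(NC(=O)c2cc(C(C)(C)C)nn2Cc2ccccc2)n1`, is the starting point of this step. In a physicochemical assay for solubility, read by nephelometry, measured as kinetic solubility, at pH 6.5 (a lower number here means a less soluble compound, a higher number a more soluble compound), compound 2 gives < 1.6 ug/mL, which is a limit of the assay rather than a number. That is the limit of < 1.6 ug/mL in this assay, at which 1 of the 3 values shown sits. Two further compounds give context. Compound 1, `NCc1csc(NC(=O)c2cnn[nH]2)n1`, gives in this assay > 100 ug/mL, again a limit and not a number; this is the limit of > 100 ug/mL in this assay, at which 1 of the 3 values shown sits. Among the compounds with values here, compound 3, `COc1ccc(C(=O)Nc2nc(CN)cs2)cc1`, gives in this assay the one plain number of the three, 25 ug/mL. So compound 2 sits at one edge of what the assay can report, and compound 1 at the other.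

Compound 4, `CC(C)(C)c1cc(C(=O)Nc2ccccn2)n(Cc2ccccc2)n1`, has not been measured. It differs from compound 2 in one place: pyridin-2-yl in place of 4-methyl-1,3-thiazol-2-yl on an amide-type nitrogen. Seen one bond further out, the change reads as (4-methyl-1,3-thiazol-2-yl)amino giving way to (pyridin-2-yl)amino, while the rest of compound 2 is kept. Within the data shown here, no pair of measured compounds differs in only one place, so there is no measured step to lean on, and the expectation rests on where compound 2 stands. The step expected here, an at least 1.2-fold higher number from compound 2 to compound 4 (0.09 log units; that floor lies within the scatter), is small and not beyond the usual scatter. Compound 4 is therefore estimated at 2 ug/mL, in a range from 1 ug/mL to 8 ug/mL, with a fair chance that the assay again reports only a limit.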

Compound 4, solubility: 6.3 ug/mL
The estimate for compound 4 lay 3.2-fold (0.50 log units) below the measured number; the range from low to high includes it.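

Pyridin-2-yl in place of 4-methyl-1,3-thiazol-2-yl on an amide-type nitrogen gives, in this assay, an at least 3.9-fold higher number from compound 2 to compound 4 (0.59 log units; beyond the scatter), so this place can move the read-out by more than the scatter even though each group has 6 heavy atoms. On these data alone, the true size of the step stays unknown, and the printed figure is only its lower bound, because compound 2 stands at a limit of the assay and not at a number: the limit of < 1.6 ug/mL in this assay, at which 1 of the 4 values shown sits. Compound 4, with its plain value of 6.3 ug/mL, gives the series a number from which later changes at this place can be read in either direction.

The two groups differ at once in ring size, in their hetero atoms and in the methyl, so this one step cannot say which of these differences matters, or why the read-out moves. As far as these compounds go, whether a 1,3-thiazol-2-yl without the methyl, or a pyridin-2-yl carrying a carboxylic acid, would shift the read-out in the same direction remains open.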